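Swapping a carbonyl for a sulfonyl on the methoxy series

This account rests on a few compounds, and the source may have more. Where it says the series, first, only, none or still open, it means among the compounds named here.

Compound 2 `Cc1cc(C)c(C(=O)N[C@@H](CNC(=O)CO[C@@H]2C[C@@H](CNc3ccccn3)N(C(=O)CC(C)(C)C)C2)C(=O)O)c(C)c1` is a cyclic inhibitor that, in an assay on a protein complex for inhibition of integrin alpha-5/beta-1 (Homo sapiens), read by ELISA (on this read-out lower numbers stand for stronger inhibition and higher numbers for weaker inhibition), gives 1.6 nM. Compound 1 `Cc1cc(C)c(S(=O)(=O)N[C@@H](CNC(=O)CO[C@@H]2C[C@@H](CNc3ccccn3)N(C(=O)CC(C)(C)C)C2)C(=O)O)c(C)c1` carries the change (2,4,6-trimethylphenyl)sulfonyl in place of (2,4,6-trimethylphenyl)carbonyl on an amine nitrogen and gives 6 nM, a step of a 3.8-fold higher number from compound 2 to compound 1 (0.57 log units; beyond the scatter). Compound 3 `COc1ccnc(NC[C@@H]2C[C@@H](OCC(=O)NC[C@H](NC(=O)c3c(C)cc(C)cc3C)C(=O)O)CN2C(=O)CC(C)(C)C)c1` differs from compound 2 by methoxy in place of hydrogen on an aromatic carbon; in this assay compound 3 gives 0.55 nM, a step of a 2.9-fold lower number from compound 2 to compound 3 (0.46 log units; beyond the scatter). Compound 4 `COc1ccnc(NC[C@@H]2C[C@@H](OCC(=O)NC[C@H](NS(=O)(=O)c3c(C)cc(C)cc3C)C(=O)O)CN2C(=O)CC(C)(C)C)c1` has not been measured; it differs from compound 3 by (2,4,6-trimethylphenyl)sulfonyl in place of (2,4,6-trimethylphenyl)carbonyl on an amine nitrogen, the same change that was made from compound 2 to compound 1, at a place described in identical words. The step from compound 3 to compound 4 is therefore expected to be a 3.8-fold higher number from compound 3 to compound 4 (0.58 log units; beyond the scatter), resting on the step of a 3.8-fold higher number from compound 2 to compound 1 (0.57 log units; beyond the scatter) seen from compound 2 to compound 1. Compound 4 is thus estimated to give 2.1 nM, between 1 nM and 4.5 nM.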

Compound 4, half-maximal inhibitory concentration: 0.9 nM
Estimate against measurement, compound 4: 2.3-fold (0.37 log units) above; measured number below the stated range.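

In this assay, putting (2,4,6-trimethylphenyl)sulfonyl in place of (2,4,6-trimethylphenyl)carbonyl gives a 1.6-fold higher number from compound 3 to compound 4 (0.21 log units; within the scatter), and this step does not differ meaningfully from the earlier one: the same change on two cores in this assay, a 3.8-fold higher number (0.57 log units; beyond the scatter) from compound 2 to compound 1 and a 1.6-fold higher number (0.21 log units; within the scatter) from compound 3 to compound 4, 2.3-fold (0.36 log units) apart, within the scatter of two such steps. The methoxy change, read here as a 6.7-fold lower number from compound 1 to compound 4 (0.82 log units; beyond the scatter), also agrees with its earlier step: the same change on two cores in this assay, a 2.9-fold lower number (0.46 log units; beyond the scatter) from compound 2 to compound 3 and a 6.7-fold lower number (0.82 log units; beyond the scatter) from compound 1 to compound 4, 2.3-fold (0.36 log units) apart, within the scatter of two such steps. Both changes therefore carried from one core to the other within the scatter, but two pairs of compounds cannot show that this holds across the series, or why.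

The compounds shown leave open whether the sulfonyl swap behaves the same with an acetyl or a longer chain in place of the trimethylphenyl ring. They also leave open how an amine or a chlorine would compare with methoxy on the aromatic carbon.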